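The source may report more compounds than this note shows. Statements on the series, on what has been measured and on what is new or still open speak of the compounds shown alone.

Measured compounds:
compound 1, `COc1cc2cc(Oc3ccc(NC(=O)Nc4cccc(C(F)(F)F)c4)cc3)c(C)nc2cc1OC`, gives 1850 nM in a functional assay on HCT-15 cells (Homo sapiens) for inhibition, read by sulforhodamine B assay, with a stated time of 48 h; a lower number here means a stronger inhibitor of growth, a higher number a weaker inhibitor of growth.
compound 2, `COc1cc2cc(Oc3ccc(NC(=O)Nc4ccc(Cl)c(C(F)(F)F)c4)cc3)c(C)nc2cc1OC`, gives 1150 nM in this assay.

On the numbers shown, compound 2 sits at the lower of the two values, with compound 1 as its only neighbour; the step of a 1.6-fold lower number from compound 1 to compound 2 (0.21 log units; within the scatter), chloro in place of hydrogen on an aromatic carbon, lies within the scatter, so the two compounds are not separable on this evidence.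

Compound 3, `COc1cc2cc(Oc3ccc(NC(=O)Nc4ccc(Cl)c(Cl)c4)cc3)c(C)nc2cc1OC`, is not yet measured. It differs from compound 2 by chloro in place of trifluoromethyl on an aromatic carbon; cut one bond further out this reads 4-chloro-3-(trifluoromethyl)phenyl to 3,4-dichlorophenyl.

Going by the values given here, no measured step exchanges trifluoromethyl for chloro, so nothing bears directly on this change. Among the compounds with values here, the only step in hand, a 1.6-fold lower number from compound 1 to compound 2 (0.21 log units; within the scatter), concerns another position and is itself within the scatter. The expected step is therefore a 1.3-fold higher number from compound 2 to compound 3 (0.12 log units; within the scatter), with no direction beyond the scatter claimed. Compound 3 is estimated in this assay at 1500 nM, expected range 600 nM to 4000 nM.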

Compound 3, concentration for 50% growth inhibition: 3560 nM
Estimate against measurement, compound 3: 2.4-fold (0.38 log units) below; the range from low to high includes it.
By their numbers in this assay, from the lowest: compounds 2, 1 and 3 (each within the scatter of the next, the first and the last beyond it).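

In this assay, going by these compounds alone, this position gives the first step that clears the scatter: chloro in place of trifluoromethyl, with the neighbouring chloro group unchanged, gives a 3.1-fold higher number from compound 2 to compound 3 (0.49 log units; beyond the scatter) and so favours trifluoromethyl over chloro at this place, in this one pair. The wider exchange of 3,4-dichlorophenyl in place of 3-(trifluoromethyl)phenyl gives a 1.9-fold higher number from compound 1 to compound 3 (0.28 log units; within the scatter) and leaves that pair unseparated, so the only single-place change shown here to matter is the one from trifluoromethyl to chloro in the presence of the second chloro group. No measurement bearing on the reason for this step is available.

Within the data shown here, whether the exchange would give a step of similar size on a ring without the second chloro group remains open, since the data hold only one pair for this change. Also open, going by these compounds, is how a nitrile, an amine or a carboxylic acid at this place would compare with trifluoromethyl and chloro, and whether any such group would move growth inhibition beyond the scatter from compound 2.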